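Thiazolidinedione amides: swapping the anilide aryl group

The compounds below may be only part of what the source reports. "The series", "measured", "known", "first", "only" and "open" are said of these compounds alone.

Measured compounds:
- compound 1 `O=C(CN1C(=O)S/C(=C/c2ccccn2)C1=O)Nc1nc2ccccc2s1`: 9300 nM
- compound 2 `O=C(COc1ccc2cc(/C=C3/SC(=O)NC3=O)ccc2c1)Nc1c(F)cc(F)cc1Br`: 1100 nM
- compound 3 `O=C(COc1ccc2ccccc2c1/C=C1\SC(=O)NC1=O)Nc1ccc([N+](=O)[O-])cc1`: 15000 nM

In an assay on isolated protein for inhibition of histone deacetylase 4 (Homo sapiens), with a stated time of 1 h (on this read-out higher numbers stand for weaker inhibition and lower numbers for stronger inhibition), compound 2 gives 1100 nM and stands lowest of the three numbers; its gaps to compound 1 and to compound 3 both lie beyond the scatter, so within this set compound 2 is the strongest inhibitor. Compound 3, which also carries a 4-nitrophenyl on the amide-type nitrogen, though on a differently substituted core, gives 15000 nM in this assay, the highest number here.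

The next compound, compound 4 `O=C(COc1ccc2cc(/C=C3/SC(=O)NC3=O)ccc2c1)Nc1ccc([N+](=O)[O-])cc1`, is not yet measured. It keeps the core of compound 2 and differs in one place: 4-nitrophenyl in place of 2-bromo-4,6-difluorophenyl on an amide-type nitrogen.

Among the compounds with values here, no step between measured compounds shares this change, so the expectation rests on the values alone. Because compound 3 gives 15000 nM with the same entering group, compound 4 is expected to sit higher than compound 2, a moderate step beyond the scatter, a 3.6-fold higher number from compound 2 to compound 4 (0.56 log units; beyond the scatter). For compound 4 the estimate in this assay is 4000 nM, with a range from 1500 nM to 12000 nM.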

Compound 4, half-maximal inhibitory concentration: 1700 nM
Beside the measured number, compound 4's estimate is 2.4-fold (0.37 log units) above it; the range from low to high includes it.
By their numbers in this assay, from the lowest: compounds 2 and 4 (each within the scatter of the next); then compounds 1 and 3 (each within the scatter of the next).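

In this assay, within the data shown here, a 1.5-fold higher number from compound 2 to compound 4 (0.19 log units; within the scatter) is the first step that changes one place only, and it leaves the number on the shared core unresolved from the scatter. On this amide-type nitrogen, 4-nitrophenyl and 2-bromo-4,6-difluorophenyl therefore read alike, even though the entering group brings hydrogen-bond acceptors and the leaving group brings bromine and fluorine on the same kind of aromatic ring. Nothing measured here bears on why the two groups read alike.

Still open, on these data alone, is how the number responds on this nitrogen to an unsubstituted phenyl, to a phenyl carrying a carboxylic acid or an amine, or to a saturated ring such as cyclohexyl. Also open, as far as these compounds go, is how 2-bromo-4,6-difluorophenyl reads on the core of compound 3.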